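Stereocentre fixed as S in an alkoxy acid series

This account rests on a few compounds, and the source may have more. Where it says the series, first, only, none or still open, it means among the compounds named here.

Measured so far in a functional assay on cells for agonist activity at Free fatty acid receptor 1 (Homo sapiens), read by calcium flux; on this read-out higher numbers stand for an effect only at larger amounts of compound and lower numbers for an effect already at smaller amounts:
compound 1 `CC#CC(CC(=O)O)c1ccc(OCc2cccc(-c3c(C)cccc3C)c2)s1` gives 210 nM in this assay
compound 2 `COC(CC(=O)O)c1ccc(OCc2cccc(-c3c(C)cccc3C)c2)s1` gives 210 nM in this assay
compound 3 `CCOC(CC(=O)O)c1ccc(OCc2cccc(-c3c(C)cccc3C)c2)s1` gives 57 nM in this assay

Compound 3 holds the lowest number of the three in this assay, and its steps from compound 1 and from compound 2 are both beyond the scatter: a 3.7-fold lower number from compound 1 to compound 3 (0.57 log units; beyond the scatter) and a 3.7-fold lower number from compound 2 to compound 3 (0.57 log units; beyond the scatter). Compound 4 `CCO[C@@H](CC(=O)O)c1ccc(OCc2cccc(-c3c(C)cccc3C)c2)s1` differs from compound 3 only in stereochemistry: the two compounds have the same atoms and bonds; at least one stereo element is drawn with a configuration in one of them and without one in the other: 1 of 1 stereo elements differ; a stereocentre at a saturated chain carbon is drawn without a configuration in compound 3 and S in compound 4. Within the data shown here, none of the measured steps concerns a stereocentre, and no other compound is drawn with a configuration, so no measured step bears directly on this change. Expected outcome for compound 4 in this assay: a 1.6-fold lower number from compound 3 to compound 4 (0.21 log units; within the scatter), i.e. an estimate of 35 nM with a range from 12 nM to 200 nM.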

Compound 4, half-maximal effective concentration: 40100 nM
Compound 4: middle estimate off by 1100-fold (3.06 log units), on the low side; the whole stated range lies below it.
By their numbers in this assay, from the lowest: compound 3; then compounds 1 and 2 (each within the scatter of the next); then compound 4.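

At the saturated chain carbon carrying the ethoxy group, the configuration matters far more in this assay than the substituent changes seen earlier, with a 700-fold higher number from compound 3 to compound 4 (2.85 log units; beyond the scatter). Compound 4 also sits well away from the other compounds without a defined configuration, with a 190-fold higher number from compound 2 to compound 4 (2.28 log units; beyond the scatter) and a 190-fold higher number from compound 1 to compound 4 (2.28 log units; beyond the scatter). The only structural difference in the step from compound 3 is at this stereocentre: the fact that one of compounds 3 and 4 is drawn with a defined configuration and the other without, at the place where they differ

Open: what the R form of compound 4 gives, and what stereoisomer composition compound 3 has. Also open, from the compounds shown here alone, is whether a propoxy group at this carbon shows the same dependence on configuration.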